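Swapping acetamido for dimethylamino: expectation for compound 4

This account rests on a few compounds, and the source may have more. Where it says the series, first, only, none or still open, it means among the compounds named here.

Measured so far:
compound 1 `CN1CCC[C@H]1[C@@H]1COc2c(cccc2-c2ccccc2)O1` — 2700 nM
compound 2 `CC(=O)Nc1ccc2c(c1)O[C@@H]([C@@H]1CCCN1C)CO2` — 8700 nM
compound 3 `CC(=O)Nc1ccc2c(c1)O[C@H]([C@@H]1CCCN1C)CO2` — 1900 nM

All three were tested in an assay on membranes from HEK293 cells for displacement of a labelled ligand from Neuronal acetylcholine receptor; alpha3/beta4 (Homo sapiens), with a stated time of 5 min; a lower number here means a stronger inhibitor, a higher number a weaker inhibitor. Compound 3 gives the lowest of the three numbers, but compound 1 sits within the scatter of it, so the two cannot be ranked. Compound 2 stands clearly apart: a 4.6-fold lower number from compound 2 to compound 3 (0.66 log units; beyond the scatter), a step that rests on the fact that compounds 2 and 3 differ only in the configuration as drawn and nothing else.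

Compound 4 `CN(C)c1ccc2c(c1)O[C@H]([C@@H]1CCCN1C)CO2` keeps the configuration of compound 3 and changes only the substituent on the aromatic ring: dimethylamino in place of acetamido on an aromatic carbon. Among the measured compounds shown here, none of the measured steps touches this position, and no pair among compounds 1 to 3 varies a group on the aromatic carbon; the only step in hand, from compound 2 to compound 3, concerns configuration and says nothing about what an acetamido or a dimethylamino group contributes. The expectation for compound 4 therefore has to be anchored on compound 3 alone, with a wide range around it. A change no larger than the scatter is expected, in no preferred direction, as a 1.3-fold higher number from compound 3 to compound 4 (0.12 log units; within the scatter). For compound 4 the estimate in this assay is 2500 nM, between 700 nM and 9000 nM.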

Compound 4, inhibition constant: 2200 nM
Beside the measured number, compound 4's estimate is 1.1-fold (0.06 log units) above it; the measured number falls inside the stated range.
By their numbers in this assay, from the lowest: compounds 3, 4 and 1 (each within the scatter of the next); then compound 2.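

In this assay, among the compounds shown here, the exchange of acetamido for dimethylamino on the aromatic carbon gives a 1.2-fold higher number from compound 3 to compound 4 (0.06 log units; within the scatter) and is the first reading of a group change at this place, with the configuration held as in compound 3. For this pair, the carbonyl and the amide hydrogen of acetamido can therefore be lost without a change beyond the scatter, so acetamido is not needed to keep the number at this level, although one exchange gives no trend for the position. For the compounds shown here, the only evidence in hand concerns configuration and gives no cause for this result.

Still open, as far as these compounds go, is whether a primary amine, a carboxylic acid or a longer chain on this aromatic carbon would also stay within the scatter of compound 3 or would move the number clearly in this assay in either direction. Also open, from the compounds shown here alone, is whether dimethylamino in the configuration of compound 2 would show a gap of the size seen in a 4.6-fold lower number from compound 2 to compound 3 (0.66 log units; beyond the scatter) or whether that gap belongs to the acetamido pair alone.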